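Pyridin-4-yl for pyridin-3-yl: expected writhing inhibition

A few compounds are considered here, and "the series" means these few. Any claim that something is new, unique, unknown or untested is made for them only; others in the source may bear on it.

The three measured compounds share one core, as in compound 1 `O=C(N/N=C/c1ccccc1)c1cccnc1Nc1cccc(C(F)(F)F)c1`, and differ only in the group on the carbon with a double bond to nitrogen. In a functional assay on the whole organism (Abdomen, strain NMRI) for inhibition, with Mus musculus as the target, in the writhing test, with a stated time of 30 min, at a dose of 10 mg/kg (on this read-out higher numbers stand for more inhibition at the one dose given (going by the name of the read-out) and lower numbers for less inhibition), compound 1 gives 66.2%. Compound 2 `O=C(N/N=C/c1cccc(Cl)c1)c1cccnc1Nc1cccc(C(F)(F)F)c1` gives 61.9%, and compound 3 `O=C(N/N=C/c1cccnc1)c1cccnc1Nc1cccc(C(F)(F)F)c1` gives 51.4%, the lowest of the three. The steps run a number 4.3 percentage points lower from compound 1 to compound 2 (within the scatter), a number 14.8 percentage points lower from compound 1 to compound 3 (beyond the scatter) and a number 10.5 percentage points lower from compound 2 to compound 3 (beyond the scatter). Compound 4 `O=C(N/N=C/c1ccncc1)c1cccnc1Nc1cccc(C(F)(F)F)c1` differs from compound 3 by pyridin-4-yl in place of pyridin-3-yl on a carbon with a double bond to nitrogen. Going by the values given here, no measured step sets pyridin-3-yl against pyridin-4-yl; the two steps into compound 3 both exchange phenyl or 3-chlorophenyl for pyridin-3-yl and are modest, but give no direction for this change. The expected step is therefore a number 1.4 percentage points lower from compound 3 to compound 4 (within the scatter), within the scatter. Compound 4 is estimated at 50%, range 36% to 64%.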

Compound 4, a percentage reported as inhibition, in the whole organism at one dose (the size of the read-out at that dose, not a potency): 85.6%
The estimate for compound 4 lay 35.6 percentage points below the measured number; measured number outside the range, above it.
By their numbers in this assay, from the lowest: compound 3; then compounds 2 and 1 (each within the scatter of the next); then compound 4.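

In this assay, pyridin-4-yl in place of pyridin-3-yl, the same atoms joined differently, gives a number 34.2 percentage points higher from compound 3 to compound 4 (beyond the scatter), so this position clearly separates the two groups. Pyridin-4-yl also stands clear of 3-chlorophenyl and phenyl, with a number 23.7 percentage points higher from compound 2 to compound 4 (beyond the scatter) and a number 19.4 percentage points higher from compound 1 to compound 4 (beyond the scatter), so a pyridinyl group here does not in itself go with a lower number. Nothing available bears on what lies behind these steps.

Still open, from the compounds shown here alone, is how pyridin-2-yl, or a phenyl carrying a carboxylic acid, would read at this position. Going by these compounds, whether the order holds at other doses also remains open.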